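Replacing 4-iodophenyl with 2,3-dihydro-1,4-benzodioxin-6-yl on the shared core

This account rests on a few compounds, and the source may have more. Where it says the series, first, only, none or still open, it means among the compounds named here.

Of the compounds shown here, three sharing one core have been measured in an ADME assay on BJ cells (Homo sapiens) for cytotoxicity, with a stated time of 72 h; a higher number here means that more compound is needed for the effect, a lower number that less compound is needed. Compound 1 `CCc1ccc(-c2nc3c(c(C)nn3-c3ccccc3)c(-c3ccccc3O)c2C#N)cc1` gives > 20000 nM, which is a limit of the assay and not a number. Compound 2 `Cc1nn(-c2ccccc2)c2nc(-c3ccccc3)c(C#N)c(-c3ccccc3O)c12` gives > 23000 nM, which is also a limit. For the measured compounds named here, compound 3 `Cc1nn(-c2ccccc2)c2nc(-c3ccc(I)cc3)c(C#N)c(-c3ccccc3O)c12` gives 19000 nM, the only actual number among the three.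

Compound 4 `Cc1nn(-c2ccccc2)c2nc(-c3ccc4c(c3)OCCO4)c(C#N)c(-c3ccccc3O)c12` has not yet been measured in this assay. It carries 2,3-dihydro-1,4-benzodioxin-6-yl in place of 4-iodophenyl on an aromatic carbon.

Going by the values given here, the steps that bear on this change all involve the same aryl group. They are an at least 1.0-fold lower number from compound 1 to compound 3 (0.02 log units; that floor lies within the scatter) and an at least 1.2-fold lower number from compound 2 to compound 3 (0.08 log units; that floor lies within the scatter), while a step that the two limits leave unreadable from compound 1 to compound 2 gives no size at all. With compound 3 at 19000 nM and those steps giving no size beyond the scatter, no step beyond the scatter is expected here. The estimated change is a 1.1-fold higher number from compound 3 to compound 4 (0.02 log units; within the scatter). The expected value for compound 4 is 20000 nM, within an estimated range of 10000 nM to 40000 nM.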

Compound 4, half-maximal effective concentration: > 20000 nM
Compound 4 gave a limit, no number; the forecaster's own chance of this, stated with the estimate: 50%; the middle value lies on the limit itself.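

In this assay, 2,3-dihydro-1,4-benzodioxin-6-yl is the first group shown at this position that carries hydrogen-bond acceptors and a non-aromatic ring, and the result sets only a floor on its effect: an at least 1.0-fold higher number from compound 3 to compound 4 (0.02 log units; that floor lies within the scatter). That floor shows no change beyond the scatter, so swapping 4-iodophenyl for this larger group produced no readable gain in cytotoxicity, and the true size of the step stays hidden. The steps linking compound 4 to compound 1 and compound 2 cannot be read, because all three compounds end at limits: the limit of > 20000 nM in this assay, at which 2 of the 4 values shown sit.

As far as these compounds go, how far the true values of compound 1, compound 2 and compound 4 lie past their limits remains open. So does whether an amine or a carboxylic acid on this aryl ring would bring a clear change in this assay.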